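This account rests on a few compounds, and the source may have more. Where it says the series, first, only, none or still open, it means among the compounds named here.

Two compounds of a shared core, an amide-linked aryl group attached to a carbonyl carbon, have been tested in a functional assay on HCC1937 cells (Homo sapiens) for antiproliferative activity, read by CCK-8 assay, with a stated time of 72 h; on this read-out lower numbers stand for stronger inhibition and higher numbers for weaker inhibition. Compound 1, `Cc1cccc(C(=O)Nc2cccc(-c3oc4cc(-c5ccc(F)cc5)ccc4c(=O)c3O)c2)c1`, carries a 3-methylphenyl on that carbonyl carbon and gives 8030 nM. Compound 2, `COc1ccc(C(=O)Nc2cccc(-c3oc4cc(-c5ccc(F)cc5)ccc4c(=O)c3O)c2)c(F)c1`, carries a 2-fluoro-4-methoxyphenyl instead and gives 24500 nM. That single exchange produced a 3.1-fold higher number from compound 1 to compound 2 (0.48 log units; beyond the scatter), so compound 2 stands with the higher of the two numbers, and compound 1 sits nearer the stronger end.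

Compound 3, `O=C(Nc1cccc(-c2oc3cc(-c4ccc(F)cc4)ccc3c(=O)c2O)c1)c1ccc([N+](=O)[O-])cc1`, is the next compound to be tested in this assay. It differs from compound 2 in one place: 4-nitrophenyl in place of 2-fluoro-4-methoxyphenyl on a carbonyl carbon. Among the compounds with values here, only one measured step exists, the one from compound 1 to compound 2, and it swapped a different pair of groups, so it offers no direct guide to replacing the 2-fluoro-4-methoxyphenyl with a 4-nitrophenyl. It does show that changing the group on this carbonyl carbon can move the number by a modest amount. With so little to go on, compound 3 is expected to land near compound 2, with a step of a 1.6-fold lower number from compound 2 to compound 3 (0.21 log units; within the scatter), and is estimated at 15000 nM, within a range of 5000 nM to 45000 nM.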

Compound 3, half-maximal inhibitory concentration: 5640 nM
Beside the measured number, compound 3's estimate is 2.7-fold (0.42 log units) above it, within the range that was stated.
By their numbers in this assay, from the lowest: compounds 3 and 1 (each within the scatter of the next); then compound 2.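

In this assay, putting 4-nitrophenyl in place of 2-fluoro-4-methoxyphenyl on this carbonyl carbon gives a 4.3-fold lower number from compound 2 to compound 3 (0.64 log units; beyond the scatter) and so shows that the weaker number of compound 2 is not shared by every substituted phenyl group at this place. Within the data shown here, measured against the 3-methylphenyl group, the same 4-nitrophenyl group gives a 1.4-fold lower number from compound 1 to compound 3 (0.15 log units; within the scatter) and so cannot be told apart from it here, which leaves 2-fluoro-4-methoxyphenyl as the only one of the three groups standing clearly apart. No measurement at hand gives a reason for this difference.

As far as these compounds go, compound 2 carries both a fluorine and a methoxy group on its ring, so it remains open whether a 2-fluorophenyl or a 4-methoxyphenyl group alone would match compound 2 or sit with the other two compounds. Also open, from the compounds shown here alone, is how a phenyl group bearing an amine or a carboxylic acid would behave on this carbonyl carbon, and whether moving the nitro group to the 3-position of the ring would change the number.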